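Phenoxy gives way to 4-isopropylpiperidin-1-yl on compound 2

The source may hold more compounds than are shown below. What is called first, only, known or untested is meant among the compounds shown, and "the series" means these compounds.

Of the compounds shown here, three have numbers so far in an ADME assay on microsomes from liver (Homo sapiens) for metabolic stability, with a stated time of 30 min, tested at 1 uM; a higher number here means that the compound lasts longer, a lower number that the compound disappears faster. Compound 1 `COc1cccc(CN2C(=O)CN(C(=O)c3cc4cc(OC)ccc4o3)C[C@@H]2CCc2ccccc2)c1` gives 0.128 h, compound 2 `COc1ccc2[nH]c(C(=O)N3CC(=O)N(Cc4ccccc4)[C@@H](COc4ccccc4)C3)cc2c1` gives 0.65 h, and compound 3 `COc1ccc2[nH]c(C(=O)N3CC(=O)N(Cc4ccccc4)[C@@H](CN4CCN(c5ccc(F)cc5)CC4)C3)cc2c1` gives 0.457 h. Compound 2 therefore sits level with compound 3, within the usual scatter of this measurement, and clearly above compound 1, beyond that scatter.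

Compound 4 `COc1ccc2[nH]c(C(=O)N3CC(=O)N(Cc4ccccc4)[C@@H](CN4CCC(C(C)C)CC4)C3)cc2c1` has not yet been measured. It differs from compound 2 in one place, where 4-isopropylpiperidin-1-yl stands in place of phenoxy on a saturated chain carbon bound to a saturated ring carbon: 4-isopropylpiperidin-1-yl in place of phenoxy on a saturated chain carbon bound to a saturated ring carbon. An aromatic ring of carbon only leaves, and a non-aromatic ring with one hetero atom enters.

For the measured compounds named here, no measured pair shows a single change like this one, so the expectation rests only on the spread of the three values, which runs from compound 1 at 0.128 h to compound 2 at 0.65 h. The expected change is a 1.9-fold lower number from compound 2 to compound 4 (0.27 log units; within the scatter), a modest fall that stays within the scatter. Compound 4 is estimated at 0.35 h, with an expected range of 0.13 h to 0.85 h.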

Compound 4, half-life: 0.317 h
Beside the measured number, compound 4's estimate is 1.1-fold (0.04 log units) above it; low and high end bracket the measured number.
By their numbers in this assay, from the lowest: compound 1; then compounds 4, 3 and 2 (each within the scatter of the next, the first and the last beyond it).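

In this assay, for the compounds shown here, the swap of phenoxy for 4-isopropylpiperidin-1-yl on a saturated chain carbon bound to a saturated ring carbon gives a 2.1-fold lower number from compound 2 to compound 4 (0.31 log units; beyond the scatter) and is the first single change that can be read at this position. It shows that the group held on this chain carbon can shift the half-life, although the step is modest. Nothing available explains why the number falls with this change.

This one swap alters several things at once: an aromatic ring of carbon only leaves, a non-aromatic ring with one hetero atom enters, and an isopropyl group comes with it. The compounds shown therefore leave open which of these matters, and how an unsubstituted piperidin-1-yl or a morpholin-4-yl on the same carbon would compare.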